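The source may hold more compounds than are shown below. What is called first, only, known or untested is meant among the compounds shown, and "the series" means these compounds.

Among the measured compounds shown here, in an assay on CHO cells for displacement of a labelled ligand from adenosine receptor A1 (Homo sapiens), read by scintillation counting, with a stated time of 90 min (on this read-out lower numbers stand for stronger inhibition and higher numbers for weaker inhibition), compound 1 `CCOc1ccc(-c2c(C#N)c(N)nc(SCc3ccn[nH]3)c2C#N)cc1` gives 21 nM, the lowest of the two numbers measured so far. For the measured compounds named here, its only measured neighbour, compound 2 `N#Cc1c(N)nc(SCc2ccn[nH]2)c(C#N)c1-c1ccc(OCC2CC2)cc1`, gives 552 nM in this assay, and the step of a 26-fold higher number from compound 1 to compound 2 (1.42 log units; beyond the scatter) shows how much a small change on the saturated chain carbon bound to an oxygen on an aromatic ring can shift the number. Compound 3 `CCOc1ccc(-c2c(C#N)c(N)nc(SCC(=O)NC)c2C#N)cc1` has not yet been measured in this assay; it keeps the ether side of compound 1 untouched and changes the other end instead: methylcarbamoyl in place of 1H-pyrazol-5-yl on a saturated chain carbon bound to a sulfur. Going by the values given here, no measured step touches this part of the shared core, so the known step between compound 1 and compound 2 gives no direct guide here. A moderate loss is expected from compound 1 to compound 3, with the step of a 3.8-fold higher number from compound 1 to compound 3 (0.58 log units; beyond the scatter), though a result within the scatter of compound 1 would not be surprising. Compound 3 is therefore expected to give about 80 nM in this assay, estimated between 15 nM and 500 nM.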

Compound 3, inhibition constant: 104 nM
For compound 3 the middle estimate is 1.3-fold (0.11 log units) below the measured one; measured number inside the range.
By their numbers in this assay, from the lowest: compound 1; then compound 3; then compound 2.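

Replacing 1H-pyrazol-5-yl with methylcarbamoyl on the saturated chain carbon bound to a sulfur gives a 5.0-fold higher number from compound 1 to compound 3 (0.69 log units; beyond the scatter) in this assay, so the number responds to this end of the molecule as well as to the ether end. A ring in this group is not needed for a fairly low number, since compound 3, which has no ring there, still gives 104 nM and the step is only modest. Nothing available explains why the 1H-pyrazol-5-yl compound gives the lower number.

Going by these compounds, it remains open whether a carboxylic acid, a longer chain or another five-membered aromatic ring, such as an imidazole, would do better or worse at this place. The compounds shown also leave open how methylcarbamoyl would behave alongside the cyclopropyl change at the ether end.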